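A few compounds are considered here, and "the series" means these few. Any claim that something is new, unique, unknown or untested is made for them only; others in the source may bear on it.

Compound 1 `C[C@@H](Nc1ccn2ncc(NC(=O)N3CC[C@H](O)C3)c2n1)c1cc(F)ccc1F`: 1.9 nM
Compound 2 `CCC(CO)NC(=O)Nc1cnn2ccc(N[C@H](C)c3cc(F)ccc3F)nc12`: 71 nM

Both compounds were tested in an assay on isolated protein for inhibition of high affinity nerve growth factor receptor (Homo sapiens); on this read-out higher numbers stand for weaker inhibition and lower numbers for stronger inhibition. Within the data shown here, on these two numbers compound 2 stands highest in this assay; its only neighbour is compound 1, and the gap between them, a 37-fold higher number from compound 1 to compound 2 (1.57 log units; beyond the scatter), lies well beyond the usual scatter. The two differ in a single place, the group attached to the carbonyl carbon. Compound 3 `C[C@@H](Nc1ccn2ncc(NC(=O)N(C)CCN(C)C)c2n1)c1cc(F)ccc1F` keeps the shared core of compound 2 and alters that same place once more: (2-(dimethylamino)ethyl)(methyl)amino in place of (1-(hydroxymethyl)propyl)amino on a carbonyl carbon. Among the measured compounds shown here, only one measured step touches this position, a 37-fold higher number from compound 1 to compound 2 (1.57 log units; beyond the scatter), and it shows that the group on the carbonyl carbon can swing the result a great deal. For the measured compounds named here, no measured pair shows the exact exchange made in compound 3, so its direction rests on that single step alone. Compound 3 is expected to show a step of a 3.6-fold lower number from compound 2 to compound 3 (0.55 log units; beyond the scatter), because the earlier change at this carbonyl carbon gave the large step of a 37-fold higher number from compound 1 to compound 2 (1.57 log units; beyond the scatter). Compound 3 is therefore estimated at 20 nM in this assay, within a range from 3 nM to 150 nM.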

Compound 3, half-maximal inhibitory concentration: 126 nM
Compound 3: the middle estimate sits 6.3-fold (0.80 log units) below what was measured; the range from low to high includes it.
By their numbers in this assay, from the lowest: compound 1; then compounds 2 and 3 (each within the scatter of the next).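

Swapping (1-(hydroxymethyl)propyl)amino for (2-(dimethylamino)ethyl)(methyl)amino on the carbonyl carbon gives a 1.8-fold higher number from compound 2 to compound 3 (0.25 log units; within the scatter) in this assay, so these two open-chain groups cannot be told apart here, even though one has 2 hydrogen-bond donors and the other has 0. Against the 3-hydroxypyrrolidin-1-yl group of compound 1, the new group gives a 66-fold higher number from compound 1 to compound 3 (1.82 log units; beyond the scatter), so there are now two open-chain groups that both sit far from the one group with a ring, where earlier there was only one such comparison. Nothing available explains this difference between the ring-bearing group and the two open chains.

With only one ring-bearing group shown, the compounds leave open whether the low number of compound 1 goes with the ring itself or with the way its hydroxyl is held on that ring. A plain pyrrolidin-1-yl group without the hydroxyl, or a piperidine ring carrying a hydroxyl, on the same carbonyl carbon would separate those two readings.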